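Shortening the side chain in a thiourea series against breast cancer cells

The source may report more compounds than this note shows. Statements on the series, on what has been measured and on what is new or still open speak of the compounds shown alone.

Compound 1 `CC(C)[C@H](NC(=S)Nc1ccccc1)c1nc2ccccc2[nH]1`: 9800 nM
Compound 2 `CC(C)C[C@H](NC(=S)Nc1ccccc1)c1nc2ccccc2[nH]1`: 25800 nM
Compound 3 `CC(C)C[C@@H](NC(=S)Nc1cc(C(F)(F)F)cc(C(F)(F)F)c1)c1nc2ccccc2[nH]1`: 91000 nM

The three measured compounds were tested in a functional assay on MCF7 cells (Homo sapiens) for cytotoxicity, read by MTT assay; on this read-out lower numbers stand for stronger inhibition and higher numbers for weaker inhibition. Compound 1 and compound 2 share the same core and differ only at one point: isopropyl in place of isobutyl on a saturated chain carbon bound to an amide-type nitrogen and an aromatic carbon. This change gave a 2.6-fold lower number from compound 2 to compound 1 (0.42 log units; beyond the scatter). Compound 3 carries a different core, and how its core differs from that of compound 2 is not broken down here; its value in this assay is the highest of the three, with compound 2 the nearest and compound 1 the furthest from it.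

Compound 4 `CC(C)[C@@H](NC(=S)Nc1cc(C(F)(F)F)cc(C(F)(F)F)c1)c1nc2ccccc2[nH]1` has not yet been measured. It relates to compound 3 exactly as compound 1 relates to compound 2: isopropyl in place of isobutyl on a saturated chain carbon bound to an amide-type nitrogen and an aromatic carbon. Since the same change lowered the number from compound 2 to compound 1 by a modest step that lay beyond the scatter, a step of similar size is expected from compound 3 to compound 4, namely a 2.6-fold lower number from compound 3 to compound 4 (0.41 log units; beyond the scatter). Because compound 3 gives 91000 nM, compound 4 is estimated to give 35000 nM in this assay, most likely between 15000 nM and 80000 nM.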

Compound 4, half-maximal inhibitory concentration: 16400 nM
Compound 4: the middle estimate sits 2.1-fold (0.33 log units) above what was measured, and the stated range covers the measured number.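

In this assay putting isopropyl in place of isobutyl gave a 5.5-fold lower number from compound 3 to compound 4 (0.74 log units; beyond the scatter) on the second core, so the number fell on both cores shown. Set beside the earlier step, the new one points the same way, and the gap between their sizes is no larger than repeat measurements could produce: the same change on two cores in this assay, a 2.6-fold lower number (0.42 log units; beyond the scatter) from compound 2 to compound 1 and a 5.5-fold lower number (0.74 log units; beyond the scatter) from compound 3 to compound 4, 2.1-fold (0.32 log units) apart, within the scatter of two such steps

Within this series, the shorter group can therefore be said to carry over from one core to the other, in direction and in roughly its size, but two pairs cannot show that this would hold on every core, and they do not explain why the number falls.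

Going by these compounds, both pairs compare only isopropyl with isobutyl, so it remains open how a methyl group, a longer chain or a cyclohexyl ring would behave on the same saturated chain carbon. On these data alone, it is also open whether the step would persist on a core bearing an amine or a carboxylic acid.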